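This account rests on a few compounds, and the source may have more. Where it says the series, first, only, none or still open, it means among the compounds named here.

Compound 1 `CS(=O)(=O)c1ccc(C(=O)N2CCC(C(=O)N3CCc4ccccc43)CC2)cc1[N+](=O)[O-]` and compound 2 `CN(Cc1ccccc1)C(=O)C1CCN(C(=O)c2ccc(S(C)(=O)=O)c([N+](=O)[O-])c2)CC1` share one core. In an assay on isolated protein for inhibition of vitamin D3 receptor (Homo sapiens), read by fluorescence polarization (a higher number here means a weaker inhibitor, a lower number a stronger inhibitor), compound 1 gives only a limit of the assay, > 60000 nM. In this assay compound 2 likewise gives only a limit, > 60000 nM. The step that the two limits leave unreadable from compound 1 to compound 2 cannot be read because of the limit of > 60000 nM in this assay, at which 2 of the 2 values shown sit. Compound 3 `CN(Cc1ccccc1F)C(=O)C1CCN(C(=O)c2ccc(S(C)(=O)=O)c([N+](=O)[O-])c2)CC1` differs from compound 2 by fluoro in place of hydrogen on an aromatic carbon, in words: fluoro in place of hydrogen on an aromatic carbon. Among the compounds with values here, no measured step gives a size for this change, so compound 3 is expected to remain at that limit, with a step that the limit leaves unreadable from compound 2 to compound 3 not beyond the scatter. Compound 3 is therefore estimated at 100000 nM, between 30000 nM and 500000 nM.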

Compound 3, half-maximal inhibitory concentration: > 60000 nM
Compound 3: only a limit was reported; the forecaster's own chance of this, stated with the estimate: 90%; the middle value is on the limit's open side.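

No step can be read among compound 1, compound 2 and compound 3, because each gives only a limit: the limit of > 60000 nM in this assay, at which 3 of the 3 values shown sit.

The compounds shown leave open whether fluoro in place of hydrogen, or either amine swap, changes anything in this assay.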